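A few compounds are considered here, and "the series" means these few. Any claim that something is new, unique, unknown or untested is made for them only; others in the source may bear on it.

Compound 1 `FC(F)(F)c1ccc(CN2CCN(Cc3cc(-c4ccc(OCc5ccccc5)cc4)on3)CC2)cc1` was examined in a functional assay on Huh-7 cells (Homo sapiens) for antiproliferative activity, read by sulforhodamine B assay, with a stated time of 72 h (on this read-out higher numbers stand for weaker inhibition and lower numbers for stronger inhibition), where compound 1 gives 1700 nM. Its companion compound 2 `FC(F)(F)c1ccc(CN2CCN(Cc3cc(-c4ccc(OCc5ccc(Cl)cc5)cc4)on3)CC2)cc1` carries chloro in place of hydrogen on an aromatic carbon, and in this assay compound 2 gives 4000 nM. Among the compounds with values here, compound 1 thus holds the lower of the two numbers measured so far, with compound 2 its only neighbour.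

Compound 3 `COc1cc(COc2ccc(-c3cc(CN4CCN(Cc5ccc(C(F)(F)F)cc5)CC4)no3)cc2)cc(OC)c1` differs from compound 1 in one place: 3,5-dimethoxyphenyl in place of phenyl on a saturated chain carbon bound to an oxygen on an aromatic ring

The change sits on a saturated chain carbon bound to an oxygen on an aromatic ring, so it touches the same benzyloxy arm that compound 2 alters. Within the data shown here, the one measured step that bears on it is a 2.4-fold higher number from compound 1 to compound 2 (0.37 log units; beyond the scatter), a modest rise in the number when a substituent was added to that arm. With a single step of a different kind to go on, the expectation for compound 3 in this assay is a number close to that of compound 1 or somewhat higher, as a 1.5-fold higher number from compound 1 to compound 3 (0.17 log units; within the scatter). Compound 3 is therefore estimated at 2500 nM, within a range from 1000 nM to 6500 nM.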

Compound 3, half-maximal inhibitory concentration: 1500 nM
The estimate for compound 3 lay 1.7-fold (0.22 log units) above the measured number; low and high end bracket the measured number.
By their numbers in this assay, from the lowest: compounds 3 and 1 (each within the scatter of the next); then compound 2.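

In this assay, the phenyl on a saturated chain carbon bound to an oxygen on an aromatic ring gives way to 3,5-dimethoxyphenyl, with 10 heavy atoms in place of 6 and 2 hydrogen-bond acceptors in place of 0, and the result is a 1.1-fold lower number from compound 1 to compound 3 (0.05 log units; within the scatter) and so no real separation between the two compounds. This position therefore accepts a larger substituted aryl group without a measurable loss, which the chloro compound alone had not shown, and among these three compounds a substituent on this ring does not by itself raise the number, with compound 2 the only one that goes that way. The two substituted rings also part from each other, as 3,5-dimethoxyphenyl in place of 4-chlorophenyl gives a 2.7-fold lower number from compound 2 to compound 3 (0.43 log units; beyond the scatter) in the same assay, and no measurement offered here accounts for that gap.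

On these data alone, what remains open is whether a single methoxy on this ring behaves like the pair, and whether chloro set alongside the methoxy groups would bring the number back up. Also unanswered is how an amine or a carboxylic acid on this ring, or a longer chain in place of the benzyl carbon, would read in this assay.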